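A few compounds are considered here, and "the series" means these few. Any claim that something is new, unique, unknown or untested is made for them only; others in the source may bear on it.

Working notes on the series. Compound 1 `CCN(CC)c1ccc(NC(=O)c2cn(Cc3c(F)cccc3F)c3ccc(=O)[nH]c3c2=O)cc1`, compound 2 `O=C(Nc1ccccc1)c1cn(Cc2c(F)cccc2F)c2ccc(=O)[nH]c2c1=O` and compound 3 `O=C(Nc1c(F)cccc1F)c1cn(Cc2c(F)cccc2F)c2ccc(=O)[nH]c2c1=O` share one core and differ only in the aryl on the amide-type nitrogen. In an in vitro assay on Sf21 cells for inhibition of high affinity 3',5'-cyclic-AMP phosphodiesterase 7A (Homo sapiens), read by scintillation proximity assay, with a stated time of 30 min (on this read-out higher numbers stand for weaker inhibition and lower numbers for stronger inhibition), compound 1 gives 46 nM and compound 2 gives 94 nM. Compound 3 reaches only the limit of this assay, > 1000 nM; this is a limit and not a number (the limit of > 1000 nM in this assay, at which 1 of the 3 values shown sits). Of the two numbers shown, compound 2 stands highest; the nearest is the modest step of a 2.0-fold higher number from compound 1 to compound 2 (0.31 log units; beyond the scatter).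

Compound 4 `O=C(NCc1ccncc1)c1ccc(NC(=O)c2cn(Cc3c(F)cccc3F)c3ccc(=O)[nH]c3c2=O)cc1` follows from compound 2 by ((pyridin-4-yl)methyl)carbamoyl in place of hydrogen on an aromatic carbon, the entering group placed para to a large group. The step that bears on this is a 2.0-fold higher number from compound 1 to compound 2 (0.31 log units; beyond the scatter), where a group at the same place was removed and the number rose modestly. The steps of an at least 10-fold higher number from compound 2 to compound 3 (1.02 log units; beyond the scatter) and an at least 21-fold higher number from compound 1 to compound 3 (1.33 log units; beyond the scatter) were large, but they alter the ring itself, not a substituent at this place, so they carry less weight here. A modest step toward a lower number in this assay, close to the scatter, is therefore expected for compound 4, namely a 1.4-fold lower number from compound 2 to compound 4 (0.16 log units; within the scatter). For compound 4 the estimated value in this assay is 65 nM, with an expected range from 25 nM to 250 nM.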

Compound 4, half-maximal inhibitory concentration: 20 nM
Estimate against measurement, compound 4: 3.3-fold (0.51 log units) above, and the stated range ends above it.
By their numbers in this assay, from the lowest: compound 4; then compound 1; then compound 2. At a limit, above all of these: compound 3.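

In this assay the aromatic carbon para to a large group now carries two different substituents that can be set against hydrogen, and both give lower numbers. The step of a 4.7-fold lower number from compound 2 to compound 4 (0.67 log units; beyond the scatter) shows that this place accepts the 10 heavy atoms of ((pyridin-4-yl)methyl)carbamoyl, including a six-membered aromatic ring with 1 hetero atom, with a gain rather than a loss. The two substituents also separate from each other, with a 2.3-fold lower number from compound 1 to compound 4 (0.36 log units; beyond the scatter) lying beyond the scatter, so the identity of the group at this place matters and not only the presence of a substituent.

On these data alone, it remains open which part of ((pyridin-4-yl)methyl)carbamoyl carries the gain, and a carboxylic acid, a primary carboxamide, a morpholine amide or a benzyl amide at the same place would help to separate the amide link from the pyridine ring, while the same group at another carbon of the ring would test how much the position itself contributes. No measured property among the data shown bears on the reason for this gain.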